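Moving the chlorine on the benzyl group

The source may report more compounds than this note shows. Statements on the series, on what has been measured and on what is new or still open speak of the compounds shown alone.

In an assay on cells for displacement of a labelled ligand from sodium- and chloride-dependent glycine transporter 1 (Homo sapiens), read by scintillation counting, with a stated time of 1 h (on this read-out higher numbers stand for weaker inhibition and lower numbers for stronger inhibition), compound 1 `Cn1cnc(S(=O)(=O)NCCOc2ccc3c(c2)[C@@H](Cc2cccc(Cl)c2)[C@@H](N)CC3)c1` gives 1.5 nM. For the measured compounds named here, the only other measured member, compound 2 `CN[C@H]1CCc2ccc(OCCNS(=O)(=O)CC3CC3)cc2[C@H]1Cc1ccccc1`, gives 1.2 nM in this assay; the two numbers lie within the usual scatter of each other, so compound 1 stands level with compound 2. Compound 3 `Cn1cnc(S(=O)(=O)NCCOc2ccc3c(c2)[C@@H](Cc2ccc(Cl)cc2)[C@@H](N)CC3)c1` differs from compound 1 by 4-chlorophenyl in place of 3-chlorophenyl on a saturated chain carbon bound to a saturated ring carbon. Going by the values given here, no measured pair carries this change, so its step size in this assay is unknown from the data. Compound 3 is expected to give 3 nM, with a range of 0.8 nM to 12 nM. The expected step of a 2.0-fold higher number from compound 1 to compound 3 (0.30 log units; within the scatter) is small, likely none beyond the scatter, leaning slightly toward a higher number.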

Compound 3, inhibition constant: 1.1 nM
Compound 3: middle estimate off by 2.7-fold (0.44 log units), on the high side; measured number inside the range.
By their numbers in this assay, from the lowest: compounds 3, 2 and 1 (each within the scatter of the next).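

In this assay, for the compounds shown here, the first one-place comparison at this position, 4-chlorophenyl in place of 3-chlorophenyl on a saturated chain carbon bound to a saturated ring carbon, gives a 1.4-fold lower number from compound 1 to compound 3 (0.13 log units; within the scatter) and so does not separate the two chlorophenyl groups. With the rest of compound 1 held fixed, the number stays level with either group at this position. No measurement at hand bears on why these two groups read level.

From the compounds shown here alone, whether fluorine, methoxy or trifluoromethyl in place of the chlorine would keep the number level remains open. So does the outcome with a pyridyl ring in place of the chlorophenyl ring.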